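The compounds below may be only part of what the source reports. "The series", "measured", "known", "first", "only" and "open" are said of these compounds alone.

Among the measured compounds shown here, in an ADME assay on C8166 cells (Homo sapiens) for cytotoxicity, read by MTT assay (a lower number here means that less compound is tolerated, a higher number that more compound is tolerated), compound 2 `Cc1cc(S(N)(=O)=O)ccc1NC(=O)COc1ccc(F)cc1Oc1ccc2ccccc2c1C` gives 56100 nM, the top of the two numbers measured so far, while compound 1 `Cc1cc(S(N)(=O)=O)ccc1NC(=O)COc1ccc(Cl)cc1Oc1ccc2cc(Br)ccc2c1` gives 31300 nM, a gap that lies within the usual scatter of such measurements. Compound 3 `Cc1cc(S(N)(=O)=O)ccc1NC(=O)COc1ccc(F)cc1Oc1ccc2cc(Br)ccc2c1Cl` differs from compound 2 in one place: 6-bromo-1-chloronaphthalen-2-yl in place of 1-methylnaphthalen-2-yl on an oxygen on an aromatic ring. For the measured compounds named here, no step between measured compounds isolates this change, so the expected step from compound 2 to compound 3 is modest, estimated at a 1.6-fold lower number from compound 2 to compound 3 (0.20 log units; within the scatter), towards a somewhat lower tolerated concentration but not clearly beyond the scatter. Compound 3 is therefore expected to give about 35000 nM, within a range from 15000 nM to 80000 nM.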

Compound 3, half-maximal cytotoxic concentration: 195000 nM
Estimate against measurement, compound 3: 5.6-fold (0.75 log units) below; measured number above the stated range.
By their numbers in this assay, from the lowest: compounds 1 and 2 (each within the scatter of the next); then compound 3.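

In this assay, among the compounds shown here, putting 6-bromo-1-chloronaphthalen-2-yl in place of 1-methylnaphthalen-2-yl gives a 3.5-fold higher number from compound 2 to compound 3 (0.54 log units; beyond the scatter) and is the only step here that lies beyond the scatter. It shows that the group on this oxygen can change how much compound the cells tolerate, and that this change raises the tolerated concentration rather than lowering it. Nothing measured here explains the shift.

Chlorine replaces the methyl and bromine appears in the same step, so the share of each remains open. Going by these compounds, how an amine or a carboxylic acid on this group would move the number also remains open.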